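A few compounds are considered here, and "the series" means these few. Any claim that something is new, unique, unknown or untested is made for them only; others in the source may bear on it.

Measured compounds:
Compound 1 `O=C(/C=C/c1coc2cc(O)ccc2c1=O)NCc1ccccc1` gives 4690 nM in a functional assay on Huh-7 cells (Homo sapiens) for inhibition, read by MTT assay, with a stated time of 48 h; on this read-out higher numbers stand for weaker inhibition and lower numbers for stronger inhibition.
Compound 2 `O=C(/C=C/c1coc2cc(O)ccc2c1=O)NCc1ccc(F)cc1` reaches only the limit > 100000 nM in this assay.
Compound 3 `COc1ccc(NC(=O)/C=C/c2coc3cc(O)ccc3c2=O)cc1` likewise reaches only the limit > 100000 nM in this assay.

Compound 3 therefore stands at the limit of this assay, as described by the limit of > 100000 nM in this assay, at which 2 of the 3 values shown sit, and no number is known for it. Compound 4 `Cc1ccccc1NC(=O)/C=C/c1coc2cc(O)ccc2c1=O` differs from it by 2-methylphenyl in place of 4-methoxyphenyl on an amide-type nitrogen. For the measured compounds named here, no measured step covers this exchange directly. Going by the values given here, the steps that bear on it indirectly are an at least 21-fold higher number from compound 1 to compound 3 (1.32 log units; beyond the scatter), which shows that an aryl amide in place of the benzyl amide drives the value to the limit, and an at least 21-fold higher number from compound 1 to compound 2 (1.32 log units; beyond the scatter), where the fluoro also did so. The step that the two limits leave unreadable from compound 2 to compound 3 gives no readable size. Because compound 3 sits at the limit named in the limit of > 100000 nM in this assay, at which 2 of the 3 values shown sit, and both recorded changes to compound 1 also moved values to that limit, compound 4 is expected to remain near the limit. The step of an at least 1.2-fold lower number from compound 3 to compound 4 (0.09 log units; that floor lies within the scatter) is thus expected to be small or unreadable. The value for compound 4 is estimated at 80000 nM, within 10000 nM to 300000 nM.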

Compound 4, half-maximal inhibitory concentration: 11100 nM
The estimate for compound 4 lay 7.2-fold (0.86 log units) above the measured number, and the stated range covers the measured number.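

In this assay, an aryl group on the amide-type nitrogen does not by itself send the value to the limit, as 2-methylphenyl in place of 4-methoxyphenyl gives an at least 9.0-fold lower number from compound 3 to compound 4 (0.95 log units; beyond the scatter). The choice of group at this position therefore matters among the aryl amides as well, and 2-methylphenyl in place of 4-fluorobenzyl gives an at least 9.0-fold lower number from compound 2 to compound 4 (0.95 log units; beyond the scatter), while 2-methylphenyl in place of benzyl costs much less, with a 2.4-fold higher number from compound 1 to compound 4 (0.37 log units; beyond the scatter). The values of compound 2 and compound 3 remain limits of the assay and not numbers, so the first two steps have only a floor and the step between those two compounds cannot be read: the limit of > 100000 nM in this assay, at which 2 of the 4 values shown sit.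

The compounds shown leave open whether the gain of compound 4 over compound 3 follows from the methyl group, from the loss of the methoxy group, or from where the group sits on the ring, since the exchange changes all of these at once. Phenyl, 4-methylphenyl and 2-methoxyphenyl on the same amide-type nitrogen would separate these readings, and how each would stand remains unknown.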